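A few compounds are considered here, and "the series" means these few. Any claim that something is new, unique, unknown or untested is made for them only; others in the source may bear on it.

In an in vitro ADME assay on microsomes from liver (Homo sapiens) for metabolic stability, read by LC-MS, tested at 1 uM (a lower number here means that the compound disappears faster, a higher number that the compound lasts longer), compound 1 `CC(C)(C)Cn1ccnc1/N=C(/Nc1ccc(Cl)c(Cl)c1)NC(C)(C)C` gives 0.202 h and compound 2 `CC(C)N/C(=N\c1nccn1CC(C)(C)C)Nc1ccc(Cl)c(Cl)c1` gives 0.338 h. The change methyl in place of hydrogen on a saturated chain carbon bound to an amine nitrogen and two saturated chain carbons made a 1.7-fold lower number from compound 2 to compound 1 (0.22 log units; within the scatter). Compound 3 `CC(C)n1ccnc1/N=C(\N)Nc1ccc(Cl)c(Cl)c1` gives > 1 h, which is a limit of this assay rather than a number, as noted in the limit of > 1 h in this assay, at which 1 of the 3 values shown sits. The difference between the core of compound 3 and that of compound 2 is not broken down here. Compound 4 `CC(C)(C)n1ccnc1/N=C(\N)Nc1ccc(Cl)c(Cl)c1` carries methyl in place of hydrogen on a saturated chain carbon bound to an aromatic nitrogen and two saturated chain carbons, the same kind of change as from compound 2 to compound 1, though here the carbon is bound to an aromatic nitrogen rather than an amine nitrogen. The expected step is a step that the limit leaves unreadable from compound 3 to compound 4, resting on a 1.7-fold lower number from compound 2 to compound 1 (0.22 log units; within the scatter) and on compound 3 standing at > 1 h. Compound 4 is estimated at 1.2 h, between 0.5 h and 3 h.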

Compound 4, half-life: > 1 h
Compound 4 ended at the assay's limit; the forecaster's own chance of this, stated with the estimate: 55%; the middle value lies beyond the limit too.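

In this assay no step can be read from compound 3 to compound 4, because both values are limits and not numbers: the limit of > 1 h in this assay, at which 2 of the 4 values shown sit. The compounds shown leave open how far apart compound 3 and compound 4 lie, and whether isopropyl to tert-butyl changes the half-life at all.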